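Series notes: chain branching on ester and amide

The source may report more compounds than this note shows. Statements on the series, on what has been measured and on what is new or still open speak of the compounds shown alone.

Measured in an assay on membranes from HeLa cells for displacement of a labelled ligand from adenosine receptor A3 (Homo sapiens), read by scintillation counting, with a stated time of 180 min, tested at 1 uM; a lower number here means less inhibition, a higher number more inhibition at the concentration tested (going by the name of the read-out):
compound 1 `CCCOC(=O)C1=C(C)NC(=S)NC1c1ccoc1`: 3%
compound 2 `CC1=C(C(=O)OCC(C)C)C(c2ccoc2)NC(=S)N1`: 1%
compound 3 `CCNC(=O)C1=C(C)NC(=O)NC1c1cccs1`: 4%

All three values lie within the scatter of one another. Compound 2 differs from compound 1 by methyl in place of hydrogen on a saturated chain carbon bound to two saturated chain carbons. The step was a number 2 percentage points lower from compound 1 to compound 2 (within the scatter). The difference between the core of compound 1 and the core of compound 3 is not broken down here. Compound 4 `CC1=C(C(=O)NC(C)C)C(c2cccs2)NC(=O)N1` is still to be measured; it differs from compound 3 by methyl in place of hydrogen on a saturated chain carbon bound to an amide-type nitrogen and a saturated chain carbon. This is the same kind of change as that from compound 1 to compound 2, but not the same: there the place is on a saturated chain carbon bound to two saturated chain carbons, here on a saturated chain carbon bound to an amide-type nitrogen and a saturated chain carbon. The earlier step was a number 2 percentage points lower from compound 1 to compound 2 (within the scatter). Because compound 3 gives 4% the expected step in this assay is a number 1 percentage points lower from compound 3 to compound 4 (within the scatter). Compound 4 is expected to give 3%, between -5% and 11%.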

Compound 4, a percentage reported as inhibition, at one concentration (the size of the read-out at that concentration, not a potency): 1%
Compound 4: the middle estimate sits 2 percentage points above what was measured; the range from low to high includes it.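

In this assay the added methyl gives a number 3 percentage points lower from compound 3 to compound 4 (within the scatter). Set beside the earlier step, the change reads alike on the two cores: the same change on two cores in this assay, a number 2 percentage points lower (within the scatter) from compound 1 to compound 2 and a number 3 percentage points lower (within the scatter) from compound 3 to compound 4, 1 percentage points apart, within the scatter of two such steps This shows only that neither step on these two cores goes beyond the scatter; it does not show that the change would carry over to a compound with a clearly higher inhibition, where a real step could be seen.

Still open, as far as these compounds go, is whether a longer chain, such as n-butyl, or a chain ending in an amine or a carboxylic acid would move the read-out beyond the scatter on either core. Also open, from the compounds shown here alone, is whether the ester and the amide would then respond alike.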